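From Compound 2 to Compound 4: Losing One Methyl

The compounds below may be only part of what the source reports. "The series", "measured", "known", "first", "only" and "open" are said of these compounds alone.

Measured in a functional assay on HOP-62 cells (Homo sapiens) for inhibition, read by sulforhodamine B assay (on this read-out higher numbers stand for weaker inhibition of growth and lower numbers for stronger inhibition of growth), so far
compound 1 `c1ccc(-c2ccc(-c3ccc(-c4nc5ccccc5[nH]4)cc3)cc2)cc1` gives 100000 nM
compound 2 `Cc1ccc2[nH]c(-c3ccc(-c4ccc(-c5ccc(N(C)C)cc5)cc4)cc3)nc2c1` gives 4230 nM
compound 3 `Oc1ccc(-c2ccc(-c3ccc(-c4nc5ccccc5[nH]4)cc3)cc2)cc1` gives 47200 nM

Compound 2 has the lowest number of the three, and compound 3 and compound 1 both stand well above it. The next compound to be measured is compound 4 `CN(C)c1ccc(-c2ccc(-c3ccc(-c4nc5ccccc5[nH]4)cc3)cc2)cc1`, which has hydrogen in place of methyl on an aromatic carbon and is otherwise the same as compound 2. The only measured step between two of these compounds is a different change, hydroxy in place of hydrogen on an aromatic carbon (a 2.1-fold lower number from compound 1 to compound 3 (0.33 log units; beyond the scatter)), and it was modest. Going by the values given here, no measured step isolates the methyl, so this step gives only a rough sense of size. Compound 1 and compound 3 also lack the methyl, but they differ from compound 2 elsewhere too, so they hint only weakly at a rise. A small step towards a higher number is therefore expected (a 1.5-fold higher number from compound 2 to compound 4 (0.19 log units; within the scatter)). In this assay compound 4 is estimated at 6500 nM with an expected range from 2200 nM to 20000 nM as its span.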

Compound 4, concentration for 50% growth inhibition: 100000 nM
For compound 4 the middle estimate is 15-fold (1.19 log units) below the measured one; measured number above the stated range.
By their numbers in this assay, from the lowest: compound 2; then compound 3; then compounds 1 and 4 (each within the scatter of the next).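

In this assay, the methyl of the 5-methyl-1H-benzimidazol-2-yl group turns out to matter far more than any change seen earlier: taking it off gives a 24-fold higher number from compound 2 to compound 4 (1.37 log units; beyond the scatter), a large step from one carbon. The dimethylamino group does not carry the low number of compound 2 by itself, since without the methyl it gives no change at the digits printed from compound 1 to compound 4 (within the scatter) and, set against hydroxy, a 2.1-fold higher number from compound 3 to compound 4 (0.33 log units; beyond the scatter). Nothing available explains why this single position weighs so heavily.

As far as these compounds go, it remains open whether the methyl would have the same effect with hydrogen or hydroxy in place of dimethylamino. Also open, from the compounds shown here alone, is whether an ethyl or a methoxy group on the same aromatic carbon would keep the number of compound 2 or lose it.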